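The source may hold more compounds than are shown below. What is called first, only, known or untested is meant among the compounds shown, and "the series" means these compounds.

Values in a physicochemical assay for lipophilicity, in phosphate buffer, measured as octanol-water partition, at pH 11.5 (a lower number here means a more polar compound, a higher number a more lipophilic compound), for the compounds measured so far:
- compound 1 `CCCCC(CC)CNC(=N)NC(=N)Nc1ccc(Cl)cc1` gives 4.93
- compound 2 `CCCCCS(=O)(=O)c1ccc(NC(=N)NC(=N)NCCCCCCNC(=N)NC(=N)Nc2ccc(S(=O)(=O)CCCCC)cc2)cc1` gives 4.1
- compound 3 `CCCCC(CC)CNC(=N)NC(=N)Nc1ccc(C)cc1` gives 4.73

Compound 1 stands at the upper end of these three numbers, level within the scatter with compound 3 and clear of compound 2. Next is compound 4 `CCNC(=N)NC(=N)Nc1ccc(Cl)cc1` with methyl in place of 1-ethylpentyl on a saturated chain carbon bound to an amine nitrogen as its only change.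

Going by the values given here, the one measured step is a number 0.20 log units lower from compound 1 to compound 3 (within the scatter) and it concerns methyl in place of chloro on an aromatic carbon, not this chain. Compound 2 is linked to compound 1 by no single change. Among the compounds with values here, no measured step therefore gauges the chain change in this assay and its size is judged from the counted loss alone, which makes the range wide. The estimated step is a number 2.53 log units lower from compound 1 to compound 4 (beyond the scatter) and this expected fall lies well beyond the scatter. Compound 4 is estimated at 2.4 with 1.8 to 3 as the expected range.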

Compound 4, partition coefficient: 2.14
The estimate for compound 4 lay 0.26 log units above the measured number, and the stated range covers the measured number.
By their numbers in this assay, from the lowest: compound 4; then compound 2; then compounds 3 and 1 (each within the scatter of the next).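

In this assay the chain position gives a number 2.79 log units lower from compound 1 to compound 4 (beyond the scatter) when the 1-ethylpentyl group gives way to methyl. The only earlier single-change step, a number 0.20 log units lower from compound 1 to compound 3 (within the scatter) for methyl in place of chloro on an aromatic carbon, stayed within the scatter, so this chain change is the first single change in the series shown to move the number beyond it. No supporting data bear on the reason for the size of this fall.

The compounds shown leave open how the number runs for groups between these two at this place, such as a butyl chain, and how a cyclohexyl group or a chain carrying a hydroxyl group compares. As far as these compounds go, it also remains open whether the same chain change gives a similar step with methyl rather than chloro on the aromatic carbon.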